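Side-chain swap on a chlorinated purine: from carbamoyl to isopropyl

This account rests on a few compounds, and the source may have more. Where it says the series, first, only, none or still open, it means among the compounds named here.

Measured compounds:
Compound 1 `O=C(O)[C@@H]1CCCN1C(=O)CN(c1nc(Cl)nc2[nH]cnc12)C1CC1` gives 23.6% in a functional assay on the whole organism (Tail, strain ICR) with Mus musculus as the target, in the tail flick test, with a stated time of 120 min, at a dose of 25 umol/kg by the oral route; a lower number here means a weaker effect, a higher number a stronger effect of the compound at the dose given.
Compound 2 `O=C(O)CC[C@H](NC(=O)CN(c1nc(Cl)nc2[nH]cnc12)C1CC1)C(=O)O` gives 30.1% in this assay.
Compound 3 `NC(=O)CC[C@H](NC(=O)CN(c1nc(Cl)nc2[nH]cnc12)C1CC1)C(=O)O` gives 17.8% in this assay.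

Among the measured compounds shown here, compound 3 sits within the scatter of compound 1 and beyond the scatter below compound 2, where the only counted step is a number 12.3 percentage points lower from compound 2 to compound 3 (beyond the scatter). Compound 4 `CC(C)[C@H](NC(=O)CN(c1nc(Cl)nc2[nH]cnc12)C1CC1)C(=O)O` differs from compound 3 by isopropyl in place of 2-carbamoylethyl on a saturated chain carbon bound to an amide-type nitrogen and a carbonyl carbon. For the measured compounds named here, no measured step exchanges a side chain of this kind, so the one known step is only loosely related. The expected step of a number 4.2 percentage points higher from compound 3 to compound 4 (within the scatter) is therefore a small upward move, not beyond the scatter. Compound 4 is estimated at 22%, with a range from 10% to 36%.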

Compound 4, a percentage reported as activity, at one dose (the size of the read-out at that dose, not a potency): 17.1%
The estimate for compound 4 lay 4.9 percentage points above the measured number, within the range that was stated.
By their numbers in this assay, from the lowest: compounds 4, 3, 1 and 2 (each within the scatter of the next, the first and the last beyond it).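

At the saturated chain carbon bound to an amide-type nitrogen and a carbonyl carbon, isopropyl in place of 2-carbamoylethyl gives a number 0.7 percentage points lower from compound 3 to compound 4 (within the scatter) in this assay, so these two side chains cannot be told apart here. Isopropyl in place of 2-carboxyethyl gives a number 13 percentage points lower from compound 2 to compound 4 (beyond the scatter), so the gap seen with the carbamoyl compound recurs with a side chain of a different kind. Replacing the 2-carboxypyrrolidin-1-yl group gives a number 6.5 percentage points lower from compound 1 to compound 4 (within the scatter).

Nothing available explains these numbers. On these data alone, whether a side chain ending in an amine, or a longer chain ending in a carboxylic acid, would reach compound 2 remains open.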